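From diethylamino to a charged ring on one chain carbon

The source may report more compounds than this note shows. Statements on the series, on what has been measured and on what is new or still open speak of the compounds shown alone.

Measured in a functional assay for inhibition, with Homo sapiens as the target; on this read-out lower numbers stand for an effect already at smaller amounts and higher numbers for an effect only at larger amounts of compound:
- compound 1 `CCCC(=O)Nc1ccc(C2=NNC(=O)CC2)cc1`: 1.44 ug/mL
- compound 2 `CCCNCC(=O)Nc1ccc(C2=NNC(=O)CC2)cc1`: about 46.4 ug/mL
- compound 3 `CCN(CC)CC(=O)Nc1ccc(C2=NNC(=O)CC2)cc1`: about 10 ug/mL

Compound 3, at about 10 ug/mL, has the second highest of the three numbers. The change to compound 4 `C[N+]1(CC(=O)Nc2ccc(C3=NNC(=O)CC3)cc2)CCCC1` is a group of 6 heavy atoms (5 carbon, 1 nitrogen; one five-membered non-aromatic ring with 1 hetero atom) in place of a group of 5 heavy atoms (4 carbon, 1 nitrogen; no ring), on a saturated chain carbon bound to a carbonyl carbon. Diethylamino, with no net charge, leaves, and a group with one five-membered non-aromatic ring and net charge +1 enters.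

Among the measured compounds shown here, three measured steps concern this same place. Propylamino gave a 32-fold higher number from compound 1 to compound 2 (1.51 log units; beyond the scatter), a large step, and diethylamino gave a 6.9-fold higher number from compound 1 to compound 3 (0.84 log units; beyond the scatter), a modest one. Swapping between those two groups gave a 4.6-fold lower number from compound 2 to compound 3 (0.67 log units; beyond the scatter), also modest. For the measured compounds named here, both groups raised the number relative to compound 1 at 1.44 ug/mL, but no measured step brings a ring to this place, so the guide is loose. A modest further rise in this assay is expected. The expected step is a 3.0-fold higher number from compound 3 to compound 4 (0.48 log units; beyond the scatter). The estimated value for compound 4 is 30 ug/mL, with an expected range from 8 ug/mL to 110 ug/mL.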

Compound 4, half-maximal effective concentration: > 46.4 ug/mL
Compound 4 gave a limit, no number; the forecaster's own chance of this, stated with the estimate: 25%; middle value at least 1.5-fold (0.18 log units) from the limit.
By their numbers in this assay, from the lowest: compound 1; then compound 3; then compound 2.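

In this assay, compound 4 gives only a limit and not a number: the limit of > 46.4 ug/mL in this assay, at which 1 of the 4 values shown sits. Even so, the limit shows an at least 4.6-fold higher number from compound 3 to compound 4 (0.66 log units; beyond the scatter), and, measured against the ethyl group, an at least 32-fold higher number from compound 1 to compound 4 (1.50 log units; beyond the scatter). So the first group here with a ring and net charge +1 also gives a higher number than ethyl, as propylamino and diethylamino did, while a number no lower from compound 2 to compound 4 (the limit leaves the size open) is all that can be read against propylamino.

The ring and the charge enter together in compound 4, so the compounds shown cannot say which of the two goes with the higher number, or how far past the limit compound 4 lies. They also leave open how an uncharged amine carrying a ring, or a longer chain in place of ethyl, would read at this place.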